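Permeability notes: benzothiazole for phenyl in the amide series

The source may report more compounds than this note shows. Statements on the series, on what has been measured and on what is new or still open speak of the compounds shown alone.

The series shares the nitro-substituted chlorobenzamide of compound 1 `O=C(Nc1cccc(-c2nc3ccccc3s2)c1)c1cc([N+](=O)[O-])c(O)cc1Cl`, compound 2 `O=C(Nc1ccccc1-c1nc2ccccc2s1)c1cc([N+](=O)[O-])ccc1Cl`, compound 3 `O=C(Nc1ccc(-c2ccccc2)cc1)c1cc([N+](=O)[O-])ccc1Cl` and the not yet measured compound 4 `O=C(Nc1ccc(-c2nc3ccccc3s2)cc1)c1cc([N+](=O)[O-])ccc1Cl`. In an ADME assay for permeability, using PAMPA, at pH 7.4 (a higher number here means that the compound crosses the layer faster, a lower number that the compound crosses the layer more slowly), compound 1 gives 307 10^-6 cm/s. For compound 2 the result in this assay is "not determined" (no result reported). In this assay, among the measured compounds shown here, compound 3 gives 26 10^-6 cm/s, the lower of the two numbers known so far, and the gap to compound 1 is beyond the scatter.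

Compound 4 differs from compound 3 in one place: 1,3-benzothiazol-2-yl in place of phenyl on an aromatic carbon. For the measured compounds named here, no step between two measured compounds covers this exact change, so the expectation rests on what compound 1 shows. Compound 1 also carries 1,3-benzothiazol-2-yl and gives 307 10^-6 cm/s, so a rise in this assay is expected; because compound 1 gives 307 10^-6 cm/s while differing from compound 4 in more than this one group, the step is expected to be smaller than the gap from compound 3 to compound 1, but still beyond the scatter. The estimated step is a 3.8-fold higher number from compound 3 to compound 4 (0.59 log units; beyond the scatter). Compound 4 is therefore expected to give about 100 10^-6 cm/s in this assay, with a likely range from 30 10^-6 cm/s to 300 10^-6 cm/s.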

Compound 4, apparent permeability: "below limit of detection" (no number reported)
For compound 4 the study gives words and no number, so the estimate cannot be set against anything.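

In this assay, among the compounds shown here, compound 4 is reported in words and not as a number, so no step from compound 3 to compound 4 can be read. No measured evidence bears on this result. The compounds shown leave open how large a change 1,3-benzothiazol-2-yl in place of phenyl brings to this read-out on the shared core.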